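Methoxy for chloro on the aniline ring of compound 3

The source may hold more compounds than are shown below. What is called first, only, known or untested is meant among the compounds shown, and "the series" means these compounds.

Compound 3 `COc1cc(-c2nn(-c3ccccc3)cc2C(=O)/C=C\Nc2ccc(Cl)cc2)cc(OC)c1OC` gives 7680 nM in a functional assay on HT-29 cells (Homo sapiens) for antiproliferative activity, read by MTT assay, with a stated time of 48 h (a lower number here means a stronger inhibitor, a higher number a weaker inhibitor), the second highest of three numbers; compound 2 `COc1ccc(N/C=C\C(=O)c2cn(-c3ccccc3)nc2-c2ccc(OC)cc2)cc1` gives 8760 nM, within the scatter of it, while compound 1 `COc1ccc(N/C=C\C(=O)c2cn(-c3ccccc3)nc2-c2ccccc2)cc1` gives 1560 nM, beyond the scatter lower. Compound 4 `COc1ccc(N/C=C\C(=O)c2cn(-c3ccccc3)nc2-c2cc(OC)c(OC)c(OC)c2)cc1` differs from compound 3 by methoxy in place of chloro on an aromatic carbon. Among the measured compounds shown here, the only measured step, a 5.6-fold higher number from compound 1 to compound 2 (0.75 log units; beyond the scatter), changes a different ring and does not bear directly on this swap. For the measured compounds named here, no step here shows chloro against methoxy on the aniline ring. Compound 4 is therefore expected to stay near compound 3, with a 1.0-fold higher number from compound 3 to compound 4 (0.02 log units; within the scatter) not beyond the scatter, and its estimated value in this assay is 8000 nM, within a range of 3000 nM to 25000 nM.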

Compound 4, half-maximal inhibitory concentration: 5780 nM
Compound 4: the middle estimate sits 1.4-fold (0.14 log units) above what was measured; the measured number falls inside the stated range.
By their numbers in this assay, from the lowest: compound 1; then compounds 4, 3 and 2 (each within the scatter of the next).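

With the 3,4,5-trimethoxyphenyl group held fixed, methoxy in place of chloro on the aromatic carbon gives a 1.3-fold lower number from compound 3 to compound 4 (0.12 log units; within the scatter) in this assay and so leaves the number within the scatter. On the other ring, 3,4,5-trimethoxyphenyl in place of 4-methoxyphenyl gives a 1.5-fold lower number from compound 2 to compound 4 (0.18 log units; within the scatter) and likewise stays within the scatter. The same group in place of phenyl gives a 3.7-fold higher number from compound 1 to compound 4 (0.57 log units; beyond the scatter) and lies beyond the scatter, in the same direction as the step to compound 2.

Nothing here gives a measured reason for these steps. On these data alone, whether an amine or a carboxylic acid at this position would behave like chloro and methoxy stays open.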